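A Further Bromo on Compound 1

This account rests on a few compounds, and the source may have more. Where it says the series, first, only, none or still open, it means among the compounds named here.

Values measured in a toxicity assay on MDCK cells (Canis lupus familiaris) for cytotoxicity, read by CCK-8 assay, with a stated time of 48 h (on this read-out lower numbers stand for higher toxicity in this test and higher numbers for lower toxicity in this test), are these.

- Compound 1 (`CCc1ccc(C(=O)NNc2c(Br)cccc2Br)cc1`) gives > 100000 nM as a limit of the assay
- Compound 2 (`COC(=O)c1ccc(C(=O)NNc2c(Br)cccc2Br)cc1`) gives 87600 nM as a number

Compound 1 stands at the limit of > 100000 nM in this assay, at which 1 of the 2 values shown sits, and so has no exact number. Compound 3 (`CCc1ccc(C(=O)NNc2c(Br)cc(Br)cc2Br)cc1`) differs from it by bromo in place of hydrogen on an aromatic carbon, which is bromo in place of hydrogen on an aromatic carbon. Among the measured compounds shown here, the only measured step, an at least 1.1-fold lower number from compound 1 to compound 2 (0.05 log units; that floor lies within the scatter), changes a different place and offers little guidance. A small move toward a lower number is therefore expected, possibly none beyond the scatter. The expected step is an at least 1.2-fold lower number from compound 1 to compound 3 (0.09 log units; that floor lies within the scatter). For compound 3 the estimated value is 80000 nM (expected range 30000 nM to 150000 nM).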

Compound 3, half-maximal cytotoxic concentration: > 100000 nM
Compound 3 was reported as a limit (the forecaster's own chance of this, stated with the estimate: 50%); middle value at least 1.2-fold (0.09 log units) away from the limit.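

Compound 1 and compound 3 both give a limit rather than an exact number, so no step between them can be read: the limit of > 100000 nM in this assay, at which 2 of the 3 values shown sit.

On these data alone, whether bromo in place of hydrogen on this aromatic carbon shifts the read-out at all remains open.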